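Stretching the Ester Chain: From Compound 1 to Compound 3

The source may report more compounds than this note shows. Statements on the series, on what has been measured and on what is new or still open speak of the compounds shown alone.

Compound 1 `CCCCCCCC(=O)OCC(=O)NCc1cc(OC)c(O)cc1I` and compound 2 `COc1cc(CNC(=O)COC(=O)/C=C(\C)CCC=C(C)C)c(I)cc1O` share one core and differ only in the acyl part of the ester. In an assay on SH-SY5Y cells for antagonist activity at transient receptor potential cation channel subfamily V member 1 (Homo sapiens), read by fluorescence and calcium flux, with a stated time of 25 min (a higher number here means a weaker inhibitor, a lower number a stronger inhibitor), compound 1 gives 1340 nM, the higher of the two numbers, while compound 2 gives 90 nM; that step, a 15-fold lower number from compound 1 to compound 2 (1.17 log units; beyond the scatter), came with 2,6-dimethylhepta-1,5-dien-1-yl in place of heptyl on the carbonyl carbon. Compound 3 `CCCCCCCCCCCC(=O)OCC(=O)NCc1cc(OC)c(O)cc1I` keeps a saturated chain but extends it: butyl in place of hydrogen on a saturated chain carbon, seven bonds along the chain from a carbonyl carbon. No measured step tests a plain extension, but the one step shown has a bulkier chain lowering the number, so a moderate drop is expected. Compound 3 is estimated at 450 nM, between 120 nM and 1700 nM, a step of a 3.0-fold lower number from compound 1 to compound 3 (0.47 log units; beyond the scatter).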

Compound 3, half-maximal inhibitory concentration: 930 nM
Compound 3: middle estimate off by 2.1-fold (0.32 log units), on the low side; low and high end bracket the measured number.
By their numbers in this assay, from the lowest: compound 2; then compounds 3 and 1 (each within the scatter of the next).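

In this assay, adding butyl to the saturated chain gives a 1.4-fold lower number from compound 1 to compound 3 (0.16 log units; within the scatter) and so leaves the number essentially unmoved at this end of the chain. Going by these compounds alone, the larger step of a 15-fold lower number from compound 1 to compound 2 (1.17 log units; beyond the scatter) therefore has no counterpart in this plain extension, which shows that a longer saturated chain does not by itself reproduce the change seen with 2,6-dimethylhepta-1,5-dien-1-yl. Nothing available explains why these two changes differ. The compounds shown leave open whether the branching or the double bonds of compound 2 matter more. They also leave open how a saturated chain with methyl branches, or a chain ending in an amine or a carboxylic acid, would fare.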